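The source may report more compounds than this note shows. Statements on the series, on what has been measured and on what is new or still open speak of the compounds shown alone.

Measured so far in an ADME assay on A549 cells (Homo sapiens) for cytotoxicity, read by resazurin assay, with a stated time of 48 h; a higher number here means that more compound is tolerated, a lower number that less compound is tolerated:
Compound 1 `CCCCCCC(C)Nc1ccc(NC(=O)c2cc(Cl)ccc2O)c(Cl)c1`: 23500 nM
Compound 2 `O=C(Nc1ccc(NCC2CC2)cc1Cl)c1cc(Cl)ccc1O`: 14400 nM
Compound 3 `O=C(Nc1ccc(NCc2cccc(C(F)(F)F)c2)cc1Cl)c1cc(Cl)ccc1O`: 13300 nM

Compound 3 gives 13300 nM and stands level with the other two compounds: all three values lie within the usual scatter of one another.

The next compound, compound 4 `O=C(Nc1ccc(NCc2ccncc2)cc1Cl)c1cc(Cl)ccc1O`, keeps the shared core and carries pyridin-4-yl in place of 3-(trifluoromethyl)phenyl on a saturated chain carbon bound to a nitrogen on an aromatic ring.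

Among the compounds with values here, two measured steps bear on this change. The closer one alters the same place, a 1.1-fold lower number from compound 2 to compound 3 (0.03 log units; within the scatter). The other exchanges the group on the nitrogen, a 1.6-fold lower number from compound 1 to compound 2 (0.21 log units; within the scatter). Both stay within the scatter, although the groups exchanged are quite different. Within the data shown here, none of the measured compounds carries an aromatic ring with a hetero atom in this place, so the data do not test this change directly.

Resting on a 1.1-fold lower number from compound 2 to compound 3 (0.03 log units; within the scatter) and a 1.6-fold lower number from compound 1 to compound 2 (0.21 log units; within the scatter), no step beyond the scatter is expected in this assay, and neither direction is favoured. The expected step is a 1.1-fold higher number from compound 3 to compound 4 (0.05 log units; within the scatter). For compound 4 the estimate is 15000 nM, with an expected range from 7000 nM to 30000 nM.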

Compound 4, half-maximal cytotoxic concentration: 65300 nM
For compound 4 the middle estimate is 4.4-fold (0.64 log units) below the measured one, outside the stated range (above it).
By their numbers in this assay, from the lowest: compounds 3, 2 and 1 (each within the scatter of the next); then compound 4.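

In this assay, the position on a saturated chain carbon bound to a nitrogen on an aromatic ring now proves able to shift the number beyond the scatter, which neither earlier step had shown: pyridin-4-yl in place of 3-(trifluoromethyl)phenyl gives a 4.9-fold higher number from compound 3 to compound 4 (0.69 log units; beyond the scatter) and pyridin-4-yl in place of cyclopropyl gives a 4.5-fold higher number from compound 2 to compound 4 (0.66 log units; beyond the scatter) at the same position. The exchange of the whole group on the nitrogen, with (pyridin-4-yl)methyl in place of 1-methylheptyl, gives a 2.8-fold higher number from compound 1 to compound 4 (0.44 log units; beyond the scatter) as well, so compound 4 stands apart from three compounds that lie level with one another, and its six-membered aromatic ring with a hetero atom is the one feature here that the others do not share. Nothing measured here accounts for this separation.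

The compounds shown leave open whether the ring nitrogen alone carries the step or whether the loss of trifluoromethyl contributes, a question that a plain phenyl on the same carbon would address. They also leave open whether the ring nitrogen's location matters, as pyridin-3-yl or pyridin-2-yl would show, and how a morpholine or a carboxylic acid would behave at this position.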